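Methoxycarbonyl added to the shared core: compound 3 to 4

The source may hold more compounds than are shown below. What is called first, only, known or untested is meant among the compounds shown, and "the series" means these compounds.

Compounds measured in a functional assay on RAW264.7 cells (Mus musculus) for inhibition, read by Griess assay, with stated times of 2 h and 12 h; a lower number here means a stronger inhibitor, a higher number a weaker inhibitor:
compound 1, `C/C=C/C=C/CCc1cc(O)c([C@@H]2O[C@H](CO)[C@@H](O)[C@H](O)[C@H]2O)c(O)c1C(=O)OC`, gives > 40000 nM, a limit of the assay.
compound 2, `CCC/C=C\C=C\CCc1cc(O)c([C@@H]2O[C@H](CO)[C@@H](O)[C@H](O)[C@H]2O)c(O)c1C(=O)OC`, gives 14000 nM.
compound 3, `CCC/C=C/C=C/CCc1cc(O)c([C@@H]2O[C@H](CO)[C@@H](O)[C@H](O)[C@H]2O)c(O)c1`, gives > 40000 nM, a limit of the assay.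

Compound 3 shows only a limit in this assay, > 40000 nM, and so stands at the limit of > 40000 nM in this assay, at which 2 of the 3 values shown sit. Compound 4, `CCC/C=C/C=C/CCc1cc(O)c([C@@H]2O[C@H](CO)[C@@H](O)[C@H](O)[C@H]2O)c(O)c1C(=O)OC`, is not yet measured; it differs from compound 3 in methoxycarbonyl in place of hydrogen on an aromatic carbon. Going by the values given here, the only measured step, an at least 2.8-fold lower number from compound 1 to compound 2 (0.45 log units; beyond the scatter), concerns the chain rather than the methoxycarbonyl group, so no measured step bears directly on the change from compound 3 to compound 4. Compound 2, which carries the methoxycarbonyl group on the shared core, gives 14000 nM in this assay. Compound 1, also carrying that group, gives only a limit, > 40000 nM. Compound 4 is therefore expected to give about 25000 nM in this assay, within 8000 nM to 60000 nM, with a real chance that only a limit is reported. The expected step of an at least 1.6-fold lower number from compound 3 to compound 4 (0.20 log units; that floor lies within the scatter) is thus, at most, modest.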

Compound 4, half-maximal inhibitory concentration: > 40000 nM
Compound 4: a limit, no number; the forecaster's own chance of this, stated with the estimate: 50%; middle value at least 1.6-fold (0.20 log units) away from the limit.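

In this assay a methoxycarbonyl group at this aromatic carbon, ortho to a hydroxy group, does not by itself give a readable value when the chain double bond is drawn E: compound 4 stays at a limit, > 40000 nM. The steps from compound 3 to compound 4 and from compound 1 to compound 4 cannot be read, as both ends of each are limits. Going by these compounds alone, the one readable step is an at least 2.8-fold higher number from compound 2 to compound 4 (0.45 log units; beyond the scatter), so within this pair the measurable value goes with the Z double bond: the fact that compounds 2 and 4 differ only in the configuration as drawn.

Going by these compounds, whether the methoxycarbonyl group is needed for the value seen with the Z double bond stays open. Also open, on these data alone, is whether a carboxylic acid or a primary amide at this carbon, or a longer chain carrying the Z double bond, would give a value rather than a limit.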